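This account rests on a few compounds, and the source may have more. Where it says the series, first, only, none or still open, it means among the compounds named here.

In a functional assay on Mahlavu cells (Homo sapiens) for inhibition, read by sulforhodamine B assay, with a stated time of 72 h (on this read-out lower numbers stand for stronger inhibition and higher numbers for weaker inhibition), compound 1 `COC1=CC(=O)C(C)=C([S@@+]([O-])c2ccc(C)cc2)C1=O` gives 14500 nM and compound 2 `CCOC1=CC(=O)C(C)=C([S@@+]([O-])c2ccc(C)cc2)C1=O` gives 18300 nM, so the two stand level, with a 1.3-fold higher number from compound 1 to compound 2 (0.10 log units; within the scatter). Among the compounds with values here, compound 3 `COC1=CC(=O)C(C)=C([S+]([O-])c2ccc(C)cc2)C1=O` keeps the same atoms and bonds as compound 1, and the only change is this: the two compounds have the same atoms and bonds; at least one stereo element is drawn with a configuration in one of them and without one in the other: 1 of 1 stereo elements differ; a stereocentre at a sulfur is drawn S in compound 1 and without a configuration in compound 3. Within the data shown here, the one measured step, a 1.3-fold higher number from compound 1 to compound 2 (0.10 log units; within the scatter), lies elsewhere in the molecule, so no measurement yet tests the sulfur stereocentre. No change beyond the scatter is expected, and the expected step is a 1.0-fold higher number from compound 1 to compound 3 (0.01 log units; within the scatter). For compound 3 the estimated value is 15000 nM, with an expected range of 8000 nM to 28000 nM.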

Compound 3, half-maximal inhibitory concentration: 11600 nM
For compound 3 the middle estimate is 1.3-fold (0.11 log units) above the measured one, and the stated range covers the measured number.
By their numbers in this assay, from the lowest: compounds 3, 1 and 2 (each within the scatter of the next).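

Within the data shown here, this is the first test of the sulfur stereocentre: this assay gives a 1.3-fold lower number from compound 1 to compound 3 (0.10 log units; within the scatter), so the two compounds stand level. Drawing the sulfur as S or with no configuration makes no difference that this read-out can separate. The comparison rests on one fact: the fact that one of compounds 1 and 3 is drawn with a defined configuration and the other without, at the place where they differ

The compounds shown leave open how the opposite sulfur configuration on its own would compare with compound 1. They also leave open how an amine on the saturated chain carbon bound to an oxygen would read.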